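The compounds below may be only part of what the source reports. "The series", "measured", "known", "first", "only" and "open" are said of these compounds alone.

Measured compounds: compound 1 `COC(=O)CNC1=CS(=O)(=O)O[C@@]12[C@@H](CO[Si](C)(C)C(C)(C)C)O[C@@H](n1cc(C)c(=O)n(C)c1=O)[C@@H]2O[Si](C)(C)C(C)(C)C` gives 105000 nM; compound 2 `Cc1cn([C@@H]2O[C@@H]3COC4(O)CS(=O)(=O)O[C@@]34[C@H]2O[Si](C)(C)C(C)(C)C)c(=O)[nH]c1=O` gives 100000 nM; compound 3 `Cc1cn([C@@H]2O[C@H](CO[Si](C)(C)C(C)(C)C)[C@@]3(OS(=O)(=O)C=C3NC(=O)c3ccccc3)[C@H]2O[Si](C)(C)C(C)(C)C)c(=O)n(C)c1=O` gives 4900 nM.

In a functional assay on MT4 cells (Homo sapiens) (a lower number here means that less compound is tolerated, a higher number that more compound is tolerated), compound 1 stands highest of the three numbers, with compound 2 within the scatter of it and compound 3 furthest away. Among the compounds with values here, the only single-place step known is a 21-fold lower number from compound 1 to compound 3 (1.33 log units; beyond the scatter), which changes the group on the amine nitrogen. Compound 4 `COC(=O)C(=O)CNC1=CS(=O)(=O)O[C@@]12[C@@H](CO[Si](C)(C)C(C)(C)C)O[C@@H](n1cc(C)c(=O)n(C)c1=O)[C@@H]2O[Si](C)(C)C(C)(C)C` differs from compound 1 in another place: methoxycarbonyl in place of methoxy on a carbonyl carbon. Within the data shown here, no measured step alters this carbonyl carbon, so the known step gives no direct guide, and the chain on the amine nitrogen is retained. Compound 4 is therefore expected to stay close to compound 1, with a 1.3-fold lower number from compound 1 to compound 4 (0.12 log units; within the scatter) likely within the scatter. The estimate for compound 4 in this assay is 80000 nM, between 30000 nM and 160000 nM.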

Compound 4, half-maximal cytotoxic concentration: 10300 nM
The estimate for compound 4 lay 7.8-fold (0.89 log units) above the measured number; the measured number lies below the stated range.
By their numbers in this assay, from the lowest: compound 3; then compound 4; then compounds 2 and 1 (each within the scatter of the next).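

In this assay, the carbonyl carbon of the chain on the amine nitrogen proved sensitive: methoxycarbonyl in place of methoxy gives a large step (a 10-fold lower number from compound 1 to compound 4 (1.01 log units; beyond the scatter)), in the same direction as the earlier benzoyl change. The ((methoxycarbonyl)carbonyl)methyl and benzoyl groups also remain distinguishable, though by a modest step (a 2.1-fold higher number from compound 3 to compound 4 (0.32 log units; beyond the scatter)). No evidence bearing on the cause of either step is available. On these data alone, whether a carboxylic acid, an amide or a longer chain at this carbonyl carbon would lower the number likewise stays open.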